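Benzoyl on the ring nitrogen: carrying a small step across cores

The compounds below may be only part of what the source reports. "The series", "measured", "known", "first", "only" and "open" are said of these compounds alone.

Compound 2 `O=C(Nc1ccccc1O)C1CCc2ccccc2N1` is the parent of this pair with a hydrogen on the ring nitrogen. In a functional assay on NCI-H23 cells (Homo sapiens) for cytotoxicity, read by sulforhodamine B assay, with a stated time of 72 h (a lower number here means a stronger inhibitor of growth, a higher number a weaker inhibitor of growth), compound 2 gives 2230 nM. Compound 1 `O=C(Nc1ccccc1O)C1CCc2ccccc2N1C(=O)c1ccccc1` carries the change benzoyl in place of hydrogen on a nitrogen on an aromatic ring in a ring on the same core, and in this assay compound 1 gives 3490 nM. Within the data shown here, the step of a 1.6-fold higher number from compound 2 to compound 1 (0.19 log units; within the scatter) is the only measured instance of this change, and it is small.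

Compound 3 `O=C(Nc1cc(C(F)(F)F)cc(C(F)(F)F)c1)C1CCc2ccccc2N1` stands on a different core; how its core differs from that of compound 2 is not broken down here. In this assay compound 3 gives 8410 nM, the highest of the three numbers, beyond the scatter from both compound 1 and compound 2.

Compound 4 `O=C(Nc1cc(C(F)(F)F)cc(C(F)(F)F)c1)C1CCc2ccccc2N1C(=O)c1ccccc1` is built from compound 3 by the change (benzoyl in place of hydrogen on a nitrogen on an aromatic ring in a ring). Compound 3 and compound 4 have the same place line as compound 2 and compound 1, so the change is the same one, made on another core. The expectation rests on a single measured step, a 1.6-fold higher number from compound 2 to compound 1 (0.19 log units; within the scatter), which is within the scatter; a step of a 1.4-fold higher number from compound 3 to compound 4 (0.15 log units; within the scatter) is therefore expected, with wide bounds since nothing shows whether the second core carries the change in the same way. For compound 4 in this assay a value of 12000 nM is estimated, between 5000 nM and 30000 nM.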

Compound 4, concentration for 50% growth inhibition: 2130 nM
Compound 4: the middle estimate sits 5.6-fold (0.75 log units) above what was measured; the whole stated range lies above it.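

In this assay, the step for benzoyl in place of hydrogen on the ring nitrogen on the core of compound 3 is a 3.9-fold lower number from compound 3 to compound 4 (0.60 log units; beyond the scatter), so the change does not carry over unchanged between the two cores, and the two steps differ: the same change on two cores in this assay, a 1.6-fold higher number (0.19 log units; within the scatter) from compound 2 to compound 1 and a 3.9-fold lower number (0.60 log units; beyond the scatter) from compound 3 to compound 4, 6.2-fold (0.79 log units) apart, beyond the scatter of two such steps

For this series, the step measured on one core is therefore a poor guide to the step on the other, and a change that does little on the core of compound 2 does a good deal more on the core of compound 3. Among these compounds, this rests on only two pairs, however, so it gives no general rule for other cores and does not show which feature of the core of compound 3 sets its step apart, nor why the two steps differ.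

Still open, on these data alone, is whether the gain on the core of compound 3 needs the benzoyl as a whole or would also appear with a smaller acyl group such as acetyl on the same nitrogen. As far as these compounds go, it is also open whether an amine or a carboxylic acid on the benzoyl ring would keep that gain, and whether either core would respond to such groups in the same way.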